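The source may hold more compounds than are shown below. What is called first, only, known or untested is meant among the compounds shown, and "the series" means these compounds.

Measured values in a functional assay on SUP-B15 cells (Homo sapiens) for antiproliferative activity, with a stated time of 72 h; a higher number here means that more compound is needed for the effect, a lower number that less compound is needed:
compound 1 `COc1ccc(-c2cc(=O)c3c(OC)cc(OC)cc3[nH]2)cc1` gives > 62000 nM, a limit of this assay rather than a number.
compound 2 `C=CCNC(=O)n1c(-c2ccc(OC)cc2)cc(=O)c2c(OC)cc(OC)cc21` gives 16000 nM.
compound 3 `COc1ccc(-c2c(Cl)c(=O)c3c(OC)cc(OC)cc3n2S(=O)(=O)c2ccc(OC)cc2)cc1` gives 17900 nM.

Compound 3 holds the highest of the two numbers in this assay, but compound 2 sits within the scatter of it, so no order between the two is claimed. Compound 1 sits at the limit of > 62000 nM in this assay, at which 1 of the 3 values shown sits. Within the data shown here, the only measured step, an at least 3.8-fold lower number from compound 1 to compound 2 (0.58 log units; beyond the scatter), concerns the aromatic nitrogen and says nothing about a halogen on the ring carbon.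

Compound 4 `COc1ccc(-c2c(I)c(=O)c3c(OC)cc(OC)cc3n2S(=O)(=O)c2ccc(OC)cc2)cc1` differs from compound 3 by iodo in place of chloro on an aromatic carbon. Among the measured compounds shown here, no measured pair tests this exchange, so the expectation is a step within the scatter, estimated as no change at the digits printed from compound 3 to compound 4 (within the scatter). Compound 4 is therefore expected to give 17900 nM, with a range from 7500 nM to 43000 nM.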

Compound 4, half-maximal effective concentration: 12300 nM
Compound 4: middle estimate off by 1.5-fold (0.16 log units), on the high side; measured number inside the range.
By their numbers in this assay, from the lowest: compounds 4, 2 and 3 (each within the scatter of the next). At a limit, above all of these: compound 1.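

In this assay the aromatic carbon two atoms from the ring nitrogen takes iodo in place of chloro without a change beyond the scatter (a 1.5-fold lower number from compound 3 to compound 4 (0.16 log units; within the scatter)). Among these compounds, this is the first measured exchange at this ring carbon, as the earlier step concerned only the aromatic nitrogen. No measured property bears on this exchange.

Still open, going by these compounds, is whether this carbon keeps the same level of activity with hydrogen, an amine or a longer chain in place of the halogen. Also open, on these data alone, is how a (4-methoxyphenyl)sulfonyl group on the ring nitrogen compares with allylcarbamoyl there when all else is equal.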